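Changing the Side Chain of Compound 2

A few compounds are considered here, and "the series" means these few. Any claim that something is new, unique, unknown or untested is made for them only; others in the source may bear on it.

In an ADME assay on S9 fraction from liver (Rattus norvegicus) for metabolic stability, read by LC-MS, using NADPH, with a stated time of 60 min, tested at 10 uM (on this read-out lower numbers stand for a less stable compound and higher numbers for a more stable compound), compound 1 `C[C@@H](O)Cc1cc(-c2ccnc3[nH]nc(C(F)(F)F)c23)cc(C2(C#N)CC2)c1` gives 42%, while compound 2 `CC(C)C(O)Cc1cc(-c2ccnc3[nH]nc(C(F)(F)F)c23)cc(C2(C#N)CC2)c1` gives 19%, the lower of the two numbers. Compound 3 `CC(=O)OCCc1cc(-c2ccnc3[nH]nc(C(F)(F)F)c23)cc(C2(C#N)CC2)c1` has not yet been measured. It differs from compound 2 on a saturated chain carbon bound to an aromatic carbon: acetoxymethyl in place of 1-hydroxy-2-methylpropyl on a saturated chain carbon bound to an aromatic carbon. Going by the values given here, only one measured step bears on this place, and it came when 1-hydroxy-2-methylpropyl took the place of 1-hydroxyethyl: a number 23 percentage points lower from compound 1 to compound 2 (beyond the scatter). Among the compounds with values here, that step shows that a change here can move the number, but it exchanged one hydroxy-bearing group for another, and no measured compound carries acetoxymethyl. It is therefore only a loose guide. The expected change stays within the scatter, with a slight lean downward: a number 6 percentage points lower from compound 2 to compound 3 (within the scatter). For compound 3, the estimate is 13%, with an expected range of 3% to 35%.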

Compound 3, percent of the compound remaining: 5%
Compound 3: middle estimate off by 8 percentage points, on the high side, within the range that was stated.
By their numbers in this assay, from the lowest: compound 3; then compound 2; then compound 1.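

In this assay, replacing a hydroxy-bearing group with acetoxymethyl gives a number 14 percentage points lower from compound 2 to compound 3 (beyond the scatter) and a number 37 percentage points lower from compound 1 to compound 3 (beyond the scatter), so both steps lie beyond the scatter. Going by these compounds alone, the earlier pair showed only that one hydroxy-bearing group could lower the number relative to another; this result shows that a group with 0 hydrogen-bond donors and 2 hydrogen-bond acceptors, on the same saturated chain carbon bound to an aromatic carbon, gives the lowest number of the three compounds. Nothing given here explains the drop.

From the compounds shown here alone, what stays open is how other groups at this place would behave, such as an amine, a carboxylic acid or a longer chain. It is also unknown whether any of them would reach or pass compound 1 at 42% in this read-out.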